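A few compounds are considered here, and "the series" means these few. Any claim that something is new, unique, unknown or untested is made for them only; others in the source may bear on it.

Measured so far in a toxicity assay on L02 cells (Homo sapiens) for cytotoxicity, read by MTT assay, with a stated time of 24 h; on this read-out lower numbers stand for higher toxicity in this test and higher numbers for lower toxicity in this test: compound 1 `CCCOC(=O)/C=C/c1ccc(OS(=O)(=O)c2ccc(Cl)cc2)c(OC)c1` gives 150000 nM; compound 2 `COc1cc(/C=C/C(=O)Nc2cccc(C)c2)ccc1OS(=O)(=O)c1ccc(Cl)cc1` gives 73500 nM; compound 3 `CCCCS(=O)(=O)Oc1ccc(/C=C/C(=O)Nc2ccccc2I)cc1OC` gives 24500 nM.

Compound 2 stands second highest of the three numbers, with compound 1 above it and compound 3 furthest below it. Among the measured compounds shown here, the one single-point step in the set runs from compound 1 to compound 2: a 2.0-fold lower number from compound 1 to compound 2 (0.31 log units; beyond the scatter).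

Compound 4 `COC(=O)/C=C/c1ccc(OS(=O)(=O)c2ccc(Cl)cc2)c(OC)c1` is not yet measured. Its difference from compound 2: methoxy in place of (3-methylphenyl)amino on a carbonyl carbon. This is the reverse in kind of the propoxy to (3-methylphenyl)amino exchange, so the step from compound 1 to compound 2 is the only one that bears on it, and it was modest. A rise of similar size is expected, a 2.0-fold higher number from compound 2 to compound 4 (0.31 log units; beyond the scatter). Compound 4 is therefore estimated at 150000 nM, with a range from 70000 nM to 320000 nM.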

Compound 4, half-maximal cytotoxic concentration: 99500 nM
For compound 4 the middle estimate is 1.5-fold (0.18 log units) above the measured one; the range from low to high includes it.
By their numbers in this assay, from the lowest: compound 3; then compounds 2, 4 and 1 (each within the scatter of the next, the first and the last beyond it).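

In this assay, methoxy in place of (3-methylphenyl)amino on a carbonyl carbon stays within the scatter (a 1.4-fold higher number from compound 2 to compound 4 (0.13 log units; within the scatter)), and so does the change from propoxy to methoxy (a 1.5-fold lower number from compound 1 to compound 4 (0.18 log units; within the scatter)). Among the compounds shown here, compound 4 thus lies within the scatter of both neighbours, so the one step beyond it (a 2.0-fold lower number from compound 1 to compound 2 (0.31 log units; beyond the scatter)) gives no clean separation between the groups at this carbonyl carbon. Nothing at hand accounts for these steps.

As far as these compounds go, whether a carboxylic acid or a longer chain at this carbonyl carbon would stay in the same range remains open.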